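The source may hold more compounds than are shown below. What is called first, only, known or untested is meant among the compounds shown, and "the series" means these compounds.

Compound 1, `CO[C@]1(C(=O)O)C=C[C@@H](NC(C)=O)[C@H]([C@H](O)[C@H](O)CO)O1`: in an assay on HEK293 cells for inhibition of sialidase-3 (Homo sapiens), read by fluorescence, with a stated time of 1 h (a higher number here means a weaker inhibitor, a lower number a stronger inhibitor), compound 1 gives > 1000000 nM, which is a limit of the assay and not a number.
Compound 2, `CO[C@@]1(C(=O)O)C=C[C@@H](NC(C)=O)[C@H]([C@H](O)[C@H](O)CO)O1`: in this assay compound 2 gives > 1000000 nM, again a limit of the assay.
Compound 3, `CCCCCCCCS[C@@]1(C(=O)O)C=C[C@@H](NC(C)=O)[C@H]([C@H](O)[C@H](O)CO)O1`: in this assay compound 3 gives > 1000000 nM, also a limit of the assay.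

Compound 1 therefore stands only at a limit, and the two other values shown are limits as well. The step that the two limits leave unreadable from compound 1 to compound 2 cannot be sized because the limit of > 1000000 nM in this assay, at which 3 of the 3 values shown sit, leaves both ends open; the same holds for a step that the two limits leave unreadable from compound 2 to compound 3. Compound 4, `CC(=O)N[C@@H]1C=C[C@](OC(C)C)(C(=O)O)O[C@H]1[C@H](O)[C@H](O)CO`, differs from compound 1 by isopropyl in place of methyl on an oxygen on a saturated carbon. Neither measured step bears directly on this change, and neither has a readable size, so the measured steps give no direction for this assay. With every value shown sitting at the limit, compound 4 is expected to remain at or beyond it. The step that the limit leaves unreadable from compound 1 to compound 4 is therefore estimated to be flat, within the scatter. Compound 4 is estimated at 2000000 nM, with a range from 300000 nM to 10000000 nM. It is most likely that the assay again reports only a limit for compound 4.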

Compound 4, half-maximal inhibitory concentration: > 1000000 nM
Compound 4: only a limit was reported; the forecaster's own chance of this, stated with the estimate: 85%; the middle value lies beyond the limit too.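

In this assay compound 4 gives > 1000000 nM, a limit of the assay and not a number. Among these compounds, compound 1 also stands only at a limit, so no step between compound 1 and compound 4 can be read. The compounds shown leave open whether methoxy to isopropoxy changes inhibition at all, since every value stands at one bound: the limit of > 1000000 nM in this assay, at which 4 of the 4 values shown sit.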